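Expected Vero-cell tolerance of compound 4

A few compounds are considered here, and "the series" means these few. Any claim that something is new, unique, unknown or untested is made for them only; others in the source may bear on it.

Compound 3 `COC(=O)c1cc(-c2cccc(NC(=O)c3ccc(/C=C/C(=O)c4cccc(C(F)(F)F)c4)cc3)c2)on1` was examined in an ADME assay on Vero cells (Chlorocebus sabaeus) for cytotoxicity, read by MTT assay, with a stated time of 72 h; a lower number here means that less compound is tolerated, a higher number that more compound is tolerated. In this assay compound 3 gives > 20 ug/mL, which is a limit of the assay and not a number. Compound 1 `COC(=O)c1cc(-c2cccc(NC(=O)c3ccc(/C=C/C(=O)c4cccc(F)c4)cc3)c2)on1` is its closest neighbour with a reading of its own. In this assay compound 1 gives > 40 ug/mL, again a limit. Compound 2 `COC(=O)c1cc(-c2cccc(NC(=O)c3ccc(C4OC4C(=O)c4ccc(Cl)cc4)cc3)c2)on1` completes the measured set. In this assay compound 2 gives > 20 ug/mL, also a limit. The step that the two limits leave unreadable from compound 1 to compound 3 and the step that the two limits leave unreadable from compound 1 to compound 2 therefore cannot be sized, as the limit of > 20 ug/mL in this assay, at which 2 of the 3 values shown sit, and the limit of > 40 ug/mL in this assay, at which 1 of the 3 values shown sits, show. Compound 4 `COC(=O)c1cc(-c2cccc(NC(=O)c3ccc(/C=C/C(=O)c4ccc(C)c(F)c4)cc3)c2)on1` has not yet been measured; it differs from compound 3 by 3-fluoro-4-methylphenyl in place of 3-(trifluoromethyl)phenyl on a carbonyl carbon. Going by the values given here, no measured step gives a readable size for a change of this kind, and every value shown sits at a limit, so no step beyond the scatter is expected in this assay. The step estimated from compound 3 to compound 4 is a step that the limit leaves unreadable from compound 3 to compound 4. Compound 4 is therefore expected to give about 40 ug/mL, with a range from 20 ug/mL to 80 ug/mL, most likely reported once more only as a limit.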

Compound 4, half-maximal cytotoxic concentration: > 50 ug/mL
Compound 4 ended at the assay's limit; the forecaster's own chance of this, stated with the estimate: 80%; at least 1.2-fold (0.09 log units) between middle value and limit.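

In this assay, going by these compounds alone, compound 4 sits at a limit, as do compound 1, compound 2 and compound 3, so no step to compound 4 can be read. The compounds shown leave open where each true half-maximal cytotoxic concentration lies, and whether 3-fluoro-4-methylphenyl in place of 3-(trifluoromethyl)phenyl changes it at all.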